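This account rests on a few compounds, and the source may have more. Where it says the series, first, only, none or still open, it means among the compounds named here.

Among the measured compounds shown here, in a functional assay on A-375 cells (Homo sapiens) for cytotoxicity, read by CCK-8 assay, with a stated time of 24 h (on this read-out higher numbers stand for weaker inhibition and lower numbers for stronger inhibition), compound 1 (`COc1ccccc1Oc1c(N)nc(-c2ccccc2)nc1Cl`) gives 7220 nM and so holds the lower of the two numbers so far, while compound 2 (`COc1ccccc1Oc1c(N)nc(-c2cccc(C)c2)nc1Cl`) gives 65300 nM in the same measurement. Compound 3 (`COc1ccc(-c2nc(N)c(Oc3ccccc3OC)c(Cl)n2)cc1`) has not yet been measured. It carries methoxy in place of hydrogen on an aromatic carbon, para to a large group, which turns phenyl into 4-methoxyphenyl (methoxy in place of hydrogen on an aromatic carbon). For the measured compounds named here, only one measured step bears on this change: methyl in place of hydrogen on an aromatic carbon gave a 9.0-fold higher number from compound 1 to compound 2 (0.96 log units; beyond the scatter) as its result. That is a single example with a different group, so it is only a weak guide. A smaller step in the same direction, towards weaker inhibition, is therefore expected, and the estimate is a 2.8-fold higher number from compound 1 to compound 3 (0.44 log units; beyond the scatter) for this change. For compound 3 the expected value is 20000 nM (estimated range 6000 nM to 70000 nM).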

Compound 3, half-maximal inhibitory concentration: > 80000 nM
Compound 3: a limit, no number; the forecaster's own chance of this, stated with the estimate: 10%; middle value at least 4.0-fold (0.60 log units) away from the limit.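

In this assay compound 3 gives > 80000 nM, which is a limit of the assay and not a number. Even so, methoxy in place of hydrogen on an aromatic carbon, para to a large group, gives an at least 11-fold higher number from compound 1 to compound 3 (1.04 log units; beyond the scatter), so with a 9.0-fold higher number from compound 1 to compound 2 (0.96 log units; beyond the scatter) both added groups now point towards weaker inhibition, and the unsubstituted phenyl of compound 1 holds the lowest number. Swapping 3-methylphenyl for 4-methoxyphenyl gives only an at least 1.2-fold higher number from compound 2 to compound 3 (0.08 log units; that floor lies within the scatter), so these two compounds cannot be ranked against each other.

On these data alone, how a fluorine atom, a hydroxyl or an amine would behave at the same place remains open. Also open, as far as these compounds go, is how much of the loss follows the group and how much its place, since 3-methylphenyl and 4-methoxyphenyl differ in both.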